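Adding Cyano to Compound 2: An Expected Cytotoxicity Readout

This account rests on a few compounds, and the source may have more. Where it says the series, first, only, none or still open, it means among the compounds named here.

Measured in an ADME assay on THP-1 cells (Homo sapiens) for cytotoxicity, read by resazurin assay, with a stated time of 48 h; a higher number here means a weaker inhibitor, a lower number a stronger inhibitor:
Compound 1 `O=c1c(O)cccn1Cc1ccccc1`: > 10 ug/mL
Compound 2 `O=c1c(O)cccn1Cc1ccc(-c2ccccc2)cc1`: > 10 ug/mL

Both entries are limits of the assay, not numbers. Compound 2 therefore has no exact position, and it gives > 10 ug/mL. Compound 3 `N#Cc1ccc(-c2ccc(Cn3cccc(O)c3=O)cc2)cc1` has cyano in place of hydrogen on an aromatic carbon, para to a large group (cyano in place of hydrogen on an aromatic carbon). Within the data shown here, the only measured step that bears on this change is a step that the two limits leave unreadable from compound 1 to compound 2, where phenyl replaces hydrogen on an aromatic carbon. It is a different change, and it gives no size to carry over. The data show (the limit of > 10 ug/mL in this assay, at which 2 of the 2 values shown sit). No step beyond the usual scatter is therefore expected in this assay, and no direction can be favoured. The expected step is a step that the limit leaves unreadable from compound 2 to compound 3. For compound 3 the estimated value is 15 ug/mL, with an expected range from 5 ug/mL to 40 ug/mL.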

Compound 3, half-maximal inhibitory concentration: > 10 ug/mL
Compound 3 gave a limit, no number (the forecaster's own chance of this, stated with the estimate: 75%); the middle value does not contradict the limit.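

Compound 2 and compound 3 both stand at a limit of this assay rather than at a number, so no step can be read between them: the limit of > 10 ug/mL in this assay, at which 3 of the 3 values shown sit.

The compounds shown leave open whether cyano in place of hydrogen on an aromatic carbon changes cytotoxicity at all.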